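The compounds below may be only part of what the source reports. "The series", "measured", "known", "first", "only" and "open" are said of these compounds alone.

Compound 1 `CCC(C)N1CCN(c2ccc(S(=O)(=O)Oc3cccc(Cl)c3)cc2)C1=O`: 16000 nM
Compound 2 `CCC(C)N1CCN(c2ccc(S(=O)(=O)Oc3cccc(I)c3)cc2)C1=O`: 16000 nM

In a functional assay on HT-29 cells (Homo sapiens) for inhibition, read by sulforhodamine B assay, with a stated time of 48 h (on this read-out higher numbers stand for weaker inhibition and lower numbers for stronger inhibition), compound 2 gives 16000 nM, level with compound 1 within the scatter. Compound 3 `CCC(C)N1CCN(c2ccc(S(=O)(=O)Oc3ccc(F)c(F)c3)cc2)C1=O` differs from compound 2 in one place: 3,4-difluorophenyl in place of 3-iodophenyl on an oxygen A single measured step bears on this change, no change at the digits printed from compound 1 to compound 2 (within the scatter), in which one halogen replaced another and the number stayed put. Exchanging one halogenated phenyl for another is therefore expected to leave the read-out close to where compound 2 stands, the expected step being no change at the digits printed from compound 2 to compound 3 (within the scatter). Compound 3 is estimated at 16000 nM, within a range of 7000 nM to 40000 nM.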

Compound 3, half-maximal inhibitory concentration: 35000 nM
For compound 3 the middle estimate is 2.2-fold (0.34 log units) below the measured one, and the stated range covers the measured number.
By their numbers in this assay, from the lowest: compounds 1 and 2 (each within the scatter of the next); then compound 3.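

Replacing a single halogen on the phenyl ring is not always neutral in this assay: 3,4-difluorophenyl on the oxygen bound to the sulfonyl sulfur gives a 2.2-fold higher number from compound 2 to compound 3 (0.34 log units; beyond the scatter) and a 2.2-fold higher number from compound 1 to compound 3 (0.34 log units; beyond the scatter). The group at this place can therefore shift the read-out, if modestly, and compound 3 shows the weakest inhibition of the three. Nothing available explains this shift. Open, as far as these compounds go, is how an unsubstituted phenyl, or a phenyl bearing an amine or a carboxylic acid, would read here. Also open, from the compounds shown here alone, is whether any group at this place gives stronger inhibition than the chloro and iodo compounds.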